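The compounds below may be only part of what the source reports. "The series", "measured", "known", "first", "only" and "open" are said of these compounds alone.

Working notes on the series. For the measured compounds named here, compound 1 `COc1cc(-c2nnc(SCC(=O)c3ccc(Cl)cc3)n2N)cc(OC)c1OC`, compound 2 `COc1cc(-c2nnc(SCC(=O)c3ccc(C)cc3)n2N)cc(OC)c1OC` and compound 3 `COc1cc(-c2nnc(SCC(=O)c3ccc(F)cc3)n2N)cc(OC)c1OC` share one core and differ only in the single group on the outer aromatic ring. In a functional assay on HeLa cells (Homo sapiens) for antiproliferative activity, read by MTT assay, with a stated time of 48 h (a lower number here means a stronger inhibitor, a higher number a weaker inhibitor), compound 1 gives 13100 nM, compound 2 gives 2940 nM and compound 3 gives 20900 nM. Compound 3 therefore carries the highest number of the three, separated from compound 2 by a 7.1-fold higher number from compound 2 to compound 3 (0.85 log units; beyond the scatter), while the other step is a 1.6-fold higher number from compound 1 to compound 3 (0.20 log units; within the scatter). Compound 4 `COc1cc(-c2nnc(SCC(=O)c3ccc(F)c(F)c3)n2N)cc(OC)c1OC` differs from compound 3 by fluoro in place of hydrogen on an aromatic carbon. Going by the values given here, no measured step adds a group where a hydrogen stood; both known steps on this ring exchange one substituent for another, so they give only an indirect guide. Compound 4 in this assay is expected to show no step beyond the scatter, a 1.0-fold lower number from compound 3 to compound 4 (0.02 log units; within the scatter). The estimate for compound 4 is 20000 nM, with a range of 8000 nM to 50000 nM.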

Compound 4, half-maximal inhibitory concentration: > 100000 nM
Compound 4 gave a limit, no number; the forecaster's own chance of this, stated with the estimate: 10%; middle value at least 5.0-fold (0.69 log units) from the limit.
By their numbers in this assay, from the lowest: compound 2; then compounds 1 and 3 (each within the scatter of the next). At a limit, above all of these: compound 4.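

In this assay compound 4 gives > 100000 nM as a limit of the assay, not a number. Here a group enters where a hydrogen stood, and fluoro ortho to a fluoro group produces an at least 4.7-fold higher number from compound 3 to compound 4 (0.67 log units; beyond the scatter) beyond what the exchanges among single groups on this ring showed. The 3,4-difluorophenyl group also yields an at least 7.6-fold higher number from compound 1 to compound 4 (0.88 log units; beyond the scatter) and an at least 34-fold higher number from compound 2 to compound 4 (1.53 log units; beyond the scatter) so this ring position is not indifferent to the added atom.

The compounds shown do not tell whether a methoxy group, an amine or a chloro group at this position would behave as fluoro does. As far as these compounds go, how far compound 4 lies past its limit stays open.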